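Pyridinyl Replacing Methylpyridazinyl on the Shared Core

A few compounds are considered here, and "the series" means these few. Any claim that something is new, unique, unknown or untested is made for them only; others in the source may bear on it.

Of the compounds shown here, three sharing one core have been measured in an assay for inhibition of kynurenine 3-monooxygenase (Homo sapiens), read by mass spectrometry, with a stated time of 1 h; on this read-out lower numbers stand for stronger inhibition and higher numbers for weaker inhibition. Compound 1 `Cc1ccc([C@@H](C)Oc2cc3onc(CCC(=O)O)c3cc2Cl)nc1` gives 3.16 nM. Compound 2 `C[C@@H](Oc1cc2onc(CCC(=O)O)c2cc1Cl)c1ccc(Cl)cn1` gives 3.16 nM. Compound 3 `Cc1ccc([C@@H](C)Oc2cc3onc(CCC(=O)O)c3cc2Cl)nn1` gives 2 nM, the lowest of the three numbers, though its steps from compound 1 and compound 2 both stay within the scatter: a 1.6-fold lower number from compound 1 to compound 3 (0.20 log units; within the scatter) and a 1.6-fold lower number from compound 2 to compound 3 (0.20 log units; within the scatter). The step of no change at the digits printed from compound 1 to compound 2 (within the scatter) shows no change either.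

Compound 4 `C[C@@H](Oc1cc2onc(CCC(=O)O)c2cc1Cl)c1ccccn1` has not yet been measured. It differs from compound 3 in one place: pyridin-2-yl in place of 6-methylpyridazin-3-yl on a saturated chain carbon bound to an oxygen on an aromatic ring and a saturated chain carbon. The two measured steps that alter the group on this saturated chain carbon, from compound 1 and from compound 2 to compound 3, were both within the scatter, so exchanging one six-membered aromatic ring for another at this place has so far moved the number little. Among the compounds with values here, no measured step removes the methyl alone or reduces the hetero atom count of this ring, so that part of the change is untested. The step of a 1.8-fold higher number from compound 3 to compound 4 (0.24 log units; within the scatter) is therefore expected to remain within the scatter, leaning if anything toward a slightly higher number. For compound 4 the estimate is 3.5 nM, with a range from 1.5 nM to 9 nM.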

Compound 4, half-maximal inhibitory concentration in the kynurenine 3-monooxygenase assay: 5.01 nM
Beside the measured number, compound 4's estimate is 1.4-fold (0.16 log units) below it, within the range that was stated.
By their numbers in the kynurenine 3-monooxygenase assay, from the lowest: compounds 3, 1, 2 and 4 (each within the scatter of the next, the first and the last beyond it).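

Within the data shown here, in the kynurenine 3-monooxygenase assay, a 2.5-fold higher number from compound 3 to compound 4 (0.40 log units; beyond the scatter) is the only step at this place that passes the scatter, while a 1.6-fold higher number from compound 2 to compound 4 (0.20 log units; within the scatter) and a 1.6-fold higher number from compound 1 to compound 4 (0.20 log units; within the scatter) stay within it, so the pyridin-2-yl and 6-methylpyridazin-3-yl compounds are told apart, but neither is told apart from compound 1 or compound 2. In a physicochemical assay for pharmacokinetics, at pH 6 (on this read-out higher numbers stand for a longer-lived compound and lower numbers for a shorter-lived compound), compound 3 gives > 1000 h, which is a limit of the assay. In the physicochemical assay compound 4 gives > 1000 h, also a limit, so the step between these two compounds cannot be read: the limit of > 1000 h in the physicochemical assay, at which 2 of the 2 values shown sit.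

On these data alone, the step from compound 3 to compound 4 changes the methyl and the ring hetero atom count together, so the share of each remains open. A pyridazin-3-yl ring without the methyl would bear on this, and a methoxy group on the pyridin-2-yl ring would test how far this place tolerates other groups.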